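A few compounds are considered here, and "the series" means these few. Any claim that something is new, unique, unknown or untested is made for them only; others in the source may bear on it.

Among the measured compounds shown here, compound 1 `COc1cc(-c2nnc(SCc3ccc(C)cc3)o2)ccc1O` is one of two compounds measured in an ADME assay on cells (Mus musculus, strain BALB/c) for cytotoxicity, read by MTT assay, with a stated time of 24 h (a lower number here means that less compound is tolerated, a higher number that more compound is tolerated), where compound 1 gives 549000 nM. Its companion, compound 2 `COc1cc(-c2nnc(SCc3ccc(Br)cc3)o2)ccc1O`, gives 455000 nM in this assay. For the measured compounds named here, the one step between them, a 1.2-fold lower number from compound 1 to compound 2 (0.08 log units; within the scatter), leaves the two values indistinguishable. Compound 1 thus holds the higher of two numbers, with compound 2 within the scatter of it.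

Compound 3 `COc1cc(-c2nnc(SCc3ccc(C)cc3)o2)ccc1OCc1ccc(C)cc1` is not yet measured. It departs from compound 1 by 4-methylbenzyl in place of hydrogen on an oxygen on an aromatic ring. Going by the values given here, no measured step concerns this oxygen; the only known step concerns an aromatic carbon and is a different change, so it offers no guide to size or direction. With nothing to lean on, the expectation is a modest move downward, a 1.8-fold lower number from compound 1 to compound 3 (0.26 log units; within the scatter), held loosely. Compound 3 is therefore estimated at 300000 nM, within a range of 100000 nM to 800000 nM.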

Compound 3, half-maximal cytotoxic concentration: 275000 nM
For compound 3 the middle estimate is 1.1-fold (0.04 log units) above the measured one; measured number inside the range.
By their numbers in this assay, from the lowest: compounds 3, 2 and 1 (each within the scatter of the next).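

In this assay, 4-methylbenzyl in place of hydrogen on the oxygen on an aromatic ring gives a 2.0-fold lower number from compound 1 to compound 3 (0.30 log units; within the scatter), so this position takes a group of 8 heavy atoms with a six-membered aromatic ring without a change that can be told from the scatter. The earlier step spoke only of an aromatic carbon, whereas this one shows that the hydroxy group of compound 1 can be replaced by (4-methylbenzyl)oxy with the number still within the scatter. Nothing shown here explains this result.

The compounds shown leave open whether an aminoethyl chain or a carboxylic acid on this oxygen would also stay within the scatter of compound 1. They also leave open whether any change at this position reaches beyond the scatter.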